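Swapping Nitro for Methoxy: An Expected Cytotoxicity Value

A few compounds are considered here, and "the series" means these few. Any claim that something is new, unique, unknown or untested is made for them only; others in the source may bear on it.

Compound 1 `COc1ccc(N(C)C(=O)N(C)c2cc(OC)c(OC)c(OC)c2)cc1`: in a functional assay on ONS-76 cells (Homo sapiens) for cytotoxicity, read by MTT assay, with a stated time of 72 h (a higher number here means a weaker inhibitor, a lower number a stronger inhibitor), compound 1 gives >= 125000 nM, which is a limit of the assay.
Compound 2 `COc1cc(N(C)C(=O)N(C)c2ccc([N+](=O)[O-])cc2)cc(OC)c1OC`: in this assay compound 2 gives >= 125000 nM, again a limit of the assay.
Compound 3 `COc1cc(NC(=O)Nc2ccc([N+](=O)[O-])cc2)cc(OC)c1OC`: in this assay compound 3 gives 35000 nM.

Going by the values given here, compound 3 thus carries the only true number in the set; the other two values stop at a limit, as the limit of >= 125000 nM in this assay, at which 2 of the 3 values shown sit, shows. Compound 1 and compound 2 share one core and differ by methoxy in place of nitro on an aromatic carbon. Both ends of that pair are limits, so the step that the two limits leave unreadable from compound 2 to compound 1 cannot be read. The difference between the core of compound 2 and the core of compound 3 is not broken down here.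

Compound 4 `COc1ccc(NC(=O)Nc2cc(OC)c(OC)c(OC)c2)cc1` is the not yet measured partner of compound 3, obtained by methoxy in place of nitro on an aromatic carbon. Among the compounds with values here, the surroundings of the exchange are described in the same words for both pairs, so this is the same change as the one from compound 2 to compound 1. Within the data shown here, that earlier step offers no readable size, so the expectation for compound 4 rests mainly on the single number for compound 3, 35000 nM. The methoxy-bearing compound 1, for its part, sits at a limit of the assay. The step from compound 3 to compound 4 is expected to be a 2.0-fold higher number from compound 3 to compound 4 (0.30 log units; within the scatter), a modest weakening. Compound 4 is therefore estimated at 70000 nM, with a likely spread from 25000 nM to 125000 nM, and a real chance that the assay reports only a limit.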

Compound 4, half-maximal inhibitory concentration: 12900 nM
Compound 4: middle estimate off by 5.4-fold (0.73 log units), on the high side; measured number below the stated range.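

In this assay, methoxy in place of nitro, on the aromatic carbon para to a large group, gives a 2.7-fold lower number from compound 3 to compound 4 (0.43 log units; beyond the scatter), so on this core the methoxy partner is the stronger inhibitor, by a modest margin that lies beyond the usual scatter. The same exchange on the shared core of compound 1 and compound 2 cannot be read, because neither end of that pair gives a true number: the limit of >= 125000 nM in this assay, at which 2 of the 4 values shown sit. This leaves one readable step on one core, which shows what the exchange does there but not whether it carries over, since there is no second size or direction to set beside it.

The compounds shown leave open whether any compound on the core of compound 1 and compound 2 would give a true number in this assay, which is what a comparison of the two cores would need. Going by these compounds alone, they also leave open how other groups at the same place on the ring would behave, for example an amine or a carboxylic acid, since nitro and methoxy are the only two groups compared there.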